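The source may hold more compounds than are shown below. What is called first, only, known or untested is meant among the compounds shown, and "the series" means these compounds.

Measured:
compound 3 `CN1CCC(n2cc(S(=O)(=O)c3cccc(F)c3)c3ccccc32)C1` — 398 nM
compound 1 `O=S(=O)(c1cccc(F)c1)c1cn(C2CCNC2)c2cc(Cl)ccc12` — "not determined" (no result reported)
compound 2 `O=S(=O)(c1cccc(F)c1)c1cn(C2CCNC2)c2ccc(Cl)cc12` — "not determined" (no result reported)

Among the compounds with values here, compound 3 is the only member of the series with a number in a functional assay on HeLa cells for agonist activity at 5-hydroxytryptamine receptor 6 (Homo sapiens), read by cAMP accumulation and immunoassay, with a stated time of 10 min; a lower number here means that less compound is needed, a higher number that more compound is needed for the effect; in this assay compound 3 gives 398 nM. Within the data shown here, compound 1 and compound 2 carry a chlorine on the shared core and have no result in this assay, so nothing can be said of how they stand against compound 3, and no step between measured compounds is available for comparison.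

Compound 4 `O=S(=O)(c1cccc(F)c1)c1cn(C2CCNC2)c2ccccc12` is the next compound to be measured in this assay. It differs from compound 3 in one place: hydrogen in place of methyl on an amine nitrogen in a ring. Among the measured compounds shown here, with no measured step of the same kind, the expectation for the step from compound 3 to compound 4 rests only on the single value of compound 3 and the small size of the change, a single carbon leaving an amine nitrogen in a ring. The step is expected to be small, most likely within the usual scatter, with a slight lean toward less compound being needed: a 1.6-fold lower number from compound 3 to compound 4 (0.20 log units; within the scatter) is the expected step.

In this assay compound 4 is thus estimated at 250 nM, expected to fall between 80 nM and 800 nM.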

Compound 4, half-maximal effective concentration: 68 nM
Compound 4: middle estimate off by 3.7-fold (0.57 log units), on the high side; measured number outside the range, below it.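

Within the data shown here, the first readable step, a 5.9-fold lower number from compound 3 to compound 4 (0.77 log units; beyond the scatter), comes from this assay and shows that this amine nitrogen in the five-membered ring is a place where removing a single methyl registers. Here the pyrrolidin-3-yl form needs less compound than the 1-methylpyrrolidin-3-yl form, but this rests on one pair on the core without chlorine and is not yet a pattern. Nothing measured here gives a reason for the size of this step.

On these data alone, the steps involving compound 1 and compound 2 cannot be read, so it remains open whether the same change would carry over to the chlorine-bearing cores. Also open, as far as these compounds go, is how an ethyl group or a longer chain on this nitrogen would stand against hydrogen and methyl.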